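The source may report more compounds than this note shows. Statements on the series, on what has been measured and on what is new or still open speak of the compounds shown alone.

Measured compounds:

Compound 1, `Fc1ccc(-n2nc(-c3ccccc3)cc2-c2ccc3cc(F)ccc3n2)cc1`: 91.6%
Compound 2, `Fc1ccc(-c2cc(-c3ccc4cc(F)ccc4n3)n(-c3ccc(F)cc3)n2)cc1`: 86.5%
Compound 3, `NS(=O)(=O)c1ccc(-n2nc(-c3ccccc3)cc2-c2ccc3cc(F)ccc3n2)cc1`: 83.6%

All three were run in an ADME assay on Huh-7 cells (Homo sapiens) for cytotoxicity, read by XTT assay, with a stated time of 3 days, tested at 200 uM; a lower number here means a stronger effect, a higher number a weaker effect of the compound at the concentration tested. Compound 1 gives 91.6% in this assay, compound 2 gives 86.5%, and compound 3 gives 83.6%. Going by the values given here, the step of a number 5.1 percentage points lower from compound 1 to compound 2 (within the scatter) and the step of a number 8 percentage points lower from compound 1 to compound 3 (within the scatter) both sit within the scatter, so the three values cannot be told apart, and no compound can be called stronger or weaker than another on this evidence.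

Compound 4, `NS(=O)(=O)c1ccc(-n2nc(-c3ccc(F)cc3)cc2-c2ccc3cc(F)ccc3n2)cc1`, has not yet been measured. It differs from compound 3 by fluoro in place of hydrogen on an aromatic carbon. The same change has already been made once in this set, from compound 1 to compound 2, where it reads fluoro in place of hydrogen on an aromatic carbon and gave the step of a number 5.1 percentage points lower from compound 1 to compound 2 (within the scatter). The place lines of the two changes agree word for word, so this is the same change. The two cores differ by sulfamoyl in place of fluoro on an aromatic carbon.

Among the compounds with values here, with only one prior example, and that one within the scatter, the expectation for compound 4 rests on compound 3 and on the earlier step of a number 5.1 percentage points lower from compound 1 to compound 2 (within the scatter). Compound 4 is expected to give 80% in this assay, with an estimated range from 68% to 92%. The step this implies, a number 3.6 percentage points lower from compound 3 to compound 4 (within the scatter), is an estimate and is expected to stay within the scatter of repeated measurements.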

Compound 4, a percentage reported as activity, at one concentration (the size of the read-out at that concentration, not a potency): 43%
Beside the measured number, compound 4's estimate is 37 percentage points above it, outside the stated range (below it).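

In this assay, fluoro in place of hydrogen gives a number 40.6 percentage points lower from compound 3 to compound 4 (beyond the scatter), and sulfamoyl in place of fluoro gives a number 43.5 percentage points lower from compound 2 to compound 4 (beyond the scatter), so the fluoro change does not carry its size from one core to the other: the same change on two cores in this assay, a number 5.1 percentage points lower (within the scatter) from compound 1 to compound 2 and a number 40.6 percentage points lower (beyond the scatter) from compound 3 to compound 4, 35.5 percentage points apart, beyond the scatter of two such steps

The sulfamoyl change reads the same way when its two cores are set side by side: the same change on two cores in this assay, a number 8 percentage points lower (within the scatter) from compound 1 to compound 3 and a number 43.5 percentage points lower (beyond the scatter) from compound 2 to compound 4, 35.5 percentage points apart, beyond the scatter of two such steps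

Within these four compounds, the effect of each change therefore depends on the group present at the other place, but this rests on a single set of four compounds and does not show why the two groups act differently together, nor whether the same result would appear on any other core.

The compounds shown carry only hydrogen or fluoro at the place para to a large group on the phenyl ring, and only fluoro or sulfamoyl on the other ring, so it remains open whether the large step needs exactly this pair of groups. As far as these compounds go, whether chloro or methoxy in place of the new fluoro, or a carboxylic acid or methylsulfonyl in place of the sulfamoyl, would give a similar reading also remains open, as does how the reading changes at other concentrations.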